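This account rests on a few compounds, and the source may have more. Where it says the series, first, only, none or still open, it means among the compounds named here.

Compound 1 `CSc1ccc(CNc2nc(SC)nc3ncccc23)cc1` and compound 2 `CCCCC[Se]c1nc(N)c2cccnc2n1` share a core that carries an amino group on one side and a small chain-bearing substituent on the other. In a functional assay on HT-29 cells (Homo sapiens) for cytotoxicity, read by MTT assay, with a stated time of 72 h (a lower number here means a stronger inhibitor of growth, a higher number a weaker inhibitor of growth), compound 1 gives 4320 nM, and compound 2 gives 5910 nM; the two numbers fall within the usual scatter of each other, so neither stands apart. Compound 3 `CSc1nc(NCc2ccccc2)c2cccnc2n1` is compound 1 with hydrogen in place of methylsulfanyl on an aromatic carbon. Going by the values given here, no measured pair shows the effect of such a change, so only a small step is expected, a 1.3-fold higher number from compound 1 to compound 3 (0.10 log units; within the scatter), in either direction or none beyond the scatter. Compound 3 is therefore estimated at 5500 nM, with a range from 2000 nM to 15000 nM.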

Compound 3, concentration for 50% growth inhibition: 87100 nM
The estimate for compound 3 lay 16-fold (1.20 log units) below the measured number; the measured number lies above the stated range.
By their numbers in this assay, from the lowest: compounds 1 and 2 (each within the scatter of the next); then compound 3.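

With hydrogen in place of methylsulfanyl on the aromatic carbon para to a large group, growth inhibition in this assay weakens sharply, with a 20-fold higher number from compound 1 to compound 3 (1.30 log units; beyond the scatter). This single change of 2 heavy atoms shows that the substituent at this position counts for much in this series, which the earlier comparison of compound 1 and compound 2 could not reveal. Nothing available explains the size of this step.

From the compounds shown here alone, whether the methylsulfanyl group itself is needed remains open, as a methoxy group, a chlorine atom or a longer chain such as ethylsulfanyl could stand at this position instead. Compound 1 and compound 3 alone cannot show whether any of these would keep the number low.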